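The compounds below may be only part of what the source reports. "The series", "measured", "known", "first", "only" and "open" are said of these compounds alone.

For the measured compounds named here, compound 1 `CC(C)=CCC[C@]1(C)/C=C/[C@@H](OC(=O)C=C(C)C)[C@](C)(O)/C=C/C(=O)/C(C[Si](C)(C)C(C)(C)C)=C\C1` gives 4000 nM in a functional assay on SMMC-7721 cells (Homo sapiens) for antiproliferative activity, read by MTT assay, with a stated time of 48 h (on this read-out lower numbers stand for stronger inhibition and higher numbers for weaker inhibition), and stands as the higher of the two numbers measured so far. Compound 2 `CC(C)=CCC[C@]1(C)/C=C/[C@@H](OC(=O)C=C(C)C)[C@](C)(O)/C=C/C(=O)/C(COC(=O)c2ccc([N+](=O)[O-])cc2)=C\C1` gives 2560 nM in this assay, a step of a 1.6-fold lower number from compound 1 to compound 2 (0.19 log units; within the scatter) that stays within the scatter. Compound 3 `CC(C)=CCC[C@]1(C)/C=C/[C@@H](OC(=O)C=C(C)C)[C@](C)(O)/C=C/C(=O)/C(C(=O)N2CCCC2)=C\C1` differs from compound 1 by a group of 7 heavy atoms (5 carbon, 1 nitrogen, 1 oxygen; one five-membered non-aromatic ring with 1 hetero atom) in place of a group of 8 heavy atoms (7 carbon, 1 silicon; no ring), on a double-bonded ring carbon. Going by the values given here, the only measured step that bears on this, from compound 1 to compound 2, exchanged the silicon-bearing group and moved the number within the scatter, so no step beyond the scatter is expected in this assay. Compound 3 is therefore expected to give 3500 nM, between 1400 nM and 9000 nM, a step of a 1.1-fold lower number from compound 1 to compound 3 (0.06 log units; within the scatter).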

Compound 3, half-maximal inhibitory concentration: 14900 nM
Beside the measured number, compound 3's estimate is 4.3-fold (0.63 log units) below it; the measured number lies above the stated range.
By their numbers in this assay, from the lowest: compounds 2 and 1 (each within the scatter of the next); then compound 3.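

In this assay, for the compounds shown here, the double-bonded ring carbon does not tolerate every change: (pyrrolidin-1-yl)carbonyl in place of the silicon-bearing group gave a 3.7-fold higher number from compound 1 to compound 3 (0.57 log units; beyond the scatter), the first step beyond the scatter here. The earlier change, on a saturated chain carbon bound to that ring carbon, gave only a 1.6-fold lower number from compound 1 to compound 2 (0.19 log units; within the scatter). No measurement shown accounts for the weaker result. As far as these compounds go, it remains open whether the higher number goes with the carbonyl or with the pyrrolidine ring; a carboxylic acid or a diethylamide at this place would help separate the two.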